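Trifluoromethyl for nitro in a nitroaniline diol series

The source may report more compounds than this note shows. Statements on the series, on what has been measured and on what is new or still open speak of the compounds shown alone.

Compound 2 `O=[N+]([O-])c1ccc(NC(CO)CO)c([N+](=O)[O-])c1` is the starting point of this step. In a functional assay on NCI-H1299 cells (Homo sapiens) for cytotoxicity (a lower number here means a stronger inhibitor, a higher number a weaker inhibitor), compound 2 gives only a limit of the assay, > 100000 nM. Compound 1 `O=[N+]([O-])c1ccccc1NC(CO)CO` is the shared core without a second ring substituent. In this assay compound 1 also gives only a limit, > 100000 nM. Compound 3 `O=[N+]([O-])c1cc(C(F)(F)F)ccc1NC(CO)CO` carries a trifluoromethyl group instead. In this assay compound 3 likewise reaches only a limit, > 100000 nM. Among the measured compounds shown here, because all three values sit at the limit of > 100000 nM in this assay, at which 3 of the 3 values shown sit, none of the measured steps can be read in size: a step that the two limits leave unreadable from compound 1 to compound 2, a step that the two limits leave unreadable from compound 1 to compound 3 and a step that the two limits leave unreadable from compound 2 to compound 3 are all unreadable.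

Compound 4 `O=[N+]([O-])c1ccc(NC(CO)CO)c(C(F)(F)F)c1` is not yet measured. It differs from compound 2 by trifluoromethyl in place of nitro on an aromatic carbon. The most closely related measured step is a step that the two limits leave unreadable from compound 2 to compound 3, the same exchange on the ring of compound 2, but its size is not readable. No direction beyond the scatter can therefore be expected in this assay, and the most likely outcome is that compound 4 again reaches only the limit. Compound 4 is estimated at 150000 nM, within a range from 40000 nM to 600000 nM. The expected step is a step that the limit leaves unreadable from compound 2 to compound 4.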

Compound 4, half-maximal inhibitory concentration: > 100000 nM
Compound 4 was reported as a limit; the forecaster's own chance of this, stated with the estimate: 85%; the middle value does not contradict the limit.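

In this assay compound 4 gives only a limit, > 100000 nM. Compound 2 is also held at a limit, so no new step can be read between compound 2 and compound 4: the limit of > 100000 nM in this assay, at which 4 of the 4 values shown sit.

The compounds shown leave open how the four compare in this assay, and whether any ring substituent on the shared core gives a measurable value.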